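The source may hold more compounds than are shown below. What is called first, only, known or untested is meant among the compounds shown, and "the series" means these compounds.

Compound 3 `CC(C)Cc1ccc(C(C)c2nnc3sc(Nc4ccccc4)nn23)cc1` stands in the middle of the three measured compounds: in a functional assay on the whole organism (strain Wistar albino) for inhibition, with Rattus norvegicus as the target, read by paw edema, with a stated time of 4 h, at a dose of 70 mg/kg by the oral route (a lower number here means less inhibition, a higher number more inhibition at the dose given (going by the name of the read-out)), compound 3 gives 68.2%. Compound 2 `CC(C)Cc1ccc(C(C)c2nnc3sc(-c4ccc(N)cc4)nn23)cc1` gives 78.8%, and compound 1 `CC(C)Cc1ccc(C(C)c2nnc3sc(-c4ccccc4N)nn23)cc1` gives 57.6%. For the measured compounds named here, the measured steps are a number 10.6 percentage points higher from compound 1 to compound 3 (beyond the scatter) and a number 10.6 percentage points lower from compound 2 to compound 3 (beyond the scatter); both move or exchange an amino group, not a fluoro, so no measured step shows what a fluoro does here. Compound 4 `CC(C)Cc1ccc(C(C)c2nnc3sc(Nc4ccc(F)cc4)nn23)cc1` differs from compound 3 by fluoro in place of hydrogen on an aromatic carbon. Going by the values given here, with no comparable step to lean on, the expectation is a change within the usual scatter, a number 1.8 percentage points higher from compound 3 to compound 4 (within the scatter). Compound 4 is therefore estimated at 70%, with a range from 58% to 82%.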

Compound 4, a percentage reported as inhibition, in the whole organism at one dose (the size of the read-out at that dose, not a potency): 28%
Estimate against measurement, compound 4: 42 percentage points above; measured number outside the range, below it.
By their numbers in this assay, from the lowest: compound 4; then compound 1; then compound 3; then compound 2.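

Swapping one hydrogen for fluoro on this aromatic carbon, para to a large group, is far from a silent change: this assay shows a number 40.2 percentage points lower from compound 3 to compound 4 (beyond the scatter). Compound 4 also sits under both aminophenyl compounds, with a number 50.8 percentage points lower from compound 2 to compound 4 (beyond the scatter) and a number 29.6 percentage points lower from compound 1 to compound 4 (beyond the scatter), so it has the lowest number of the four. Nothing shown here accounts for this drop.

Going by these compounds, whether a chloro, a methyl or a methoxy at the same carbon would cost as much stays open. So does what fluoro does at other carbons of that ring.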